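Cytotoxicity of Salicylanilide Amines: From Cyclopropyl to Aryl

This account rests on a few compounds, and the source may have more. Where it says the series, first, only, none or still open, it means among the compounds named here.

Compound 1 `O=C(Nc1ccc(NCC2CC2)cc1Cl)c1cc(Cl)ccc1O`: 14400 nM in an ADME assay on A549 cells (Homo sapiens) for cytotoxicity, read by resazurin assay, with a stated time of 48 h; a lower number here means that less compound is tolerated, a higher number that more compound is tolerated
Compound 2 `O=C(Nc1ccc(N(CC2CC2)CC2CC2)cc1Cl)c1cc(Cl)ccc1O`: 12800 nM in this assay

Compound 1 and compound 2 lie within the scatter of each other, separated only by a 1.1-fold lower number from compound 1 to compound 2 (0.05 log units; within the scatter). Compound 3 `O=C(Nc1ccc(NCc2ccc(C(F)(F)F)cc2)cc1Cl)c1cc(Cl)ccc1O` differs from compound 1 by 4-(trifluoromethyl)phenyl in place of cyclopropyl on a saturated chain carbon bound to a nitrogen on an aromatic ring. Among the measured compounds shown here, the only measured step, the one from compound 1 to compound 2, touches the same nitrogen but adds rather than exchanges a group, so it bears on this change only loosely; it stayed within the scatter. A step of a 1.3-fold lower number from compound 1 to compound 3 (0.12 log units; within the scatter) is therefore expected, with no clear direction. Compound 3 is expected to give 11000 nM, between 4500 nM and 28000 nM.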

Compound 3, half-maximal cytotoxic concentration: 62700 nM
Beside the measured number, compound 3's estimate is 5.7-fold (0.76 log units) below it, outside the stated range (above it).
By their numbers in this assay, from the lowest: compounds 2 and 1 (each within the scatter of the next); then compound 3.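

Among the compounds shown here, at this place, on a saturated chain carbon bound to a nitrogen on an aromatic ring, 4-(trifluoromethyl)phenyl in place of cyclopropyl gives a 4.4-fold higher number from compound 1 to compound 3 (0.64 log units; beyond the scatter) in this assay, the only step here beyond the scatter. The group on this nitrogen can therefore shift the tolerated concentration, which the step to compound 2 did not show. Nothing available accounts for this shift.

From the compounds shown here alone, compound 3 brings in the aromatic ring and the trifluoromethyl group together, so their separate contributions remain open. A plain phenyl at the same place would bear on that question.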